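Chloro in Place of Methyl on Compound 3

The source may hold more compounds than are shown below. What is called first, only, known or untested is meant among the compounds shown, and "the series" means these compounds.

Compound 1 `c1cc(C2=NNC(c3ccc(N4CCCCC4)cc3)C2)cs1` carries a thiophen-3-yl group on a carbon with a double bond to nitrogen. In an ADME assay on PBMC cells (Homo sapiens) for cytotoxicity, with a stated time of 5 days (on this read-out lower numbers stand for stronger inhibition and higher numbers for weaker inhibition), compound 1 reaches only the limit of the assay, > 100000 nM, a limit and not a number (the limit of > 100000 nM in this assay, at which 1 of the 3 values shown sits). Compound 2 `Cc1ccsc1C1=NNC(c2ccc(N3CCCCC3)cc2)C1` gives 11000 nM and compound 3 `Cc1ccc(C2=NNC(c3ccc(N4CCCCC4)cc3)C2)s1` gives 86400 nM. The step of an at least 9.0-fold lower number from compound 1 to compound 2 (0.95 log units; beyond the scatter) is the largest shift seen, while an at least 1.1-fold lower number from compound 1 to compound 3 (0.06 log units; that floor lies within the scatter) and a 7.9-fold higher number from compound 2 to compound 3 (0.90 log units; beyond the scatter) describe the rest. Among the two measured numbers, compound 3 stands highest, with compound 2 its nearest neighbour.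

Compound 4 `Clc1ccc(C2=NNC(c3ccc(N4CCCCC4)cc3)C2)s1` differs from compound 3 by chloro in place of methyl on an aromatic carbon. Going by the values given here, none of the measured steps exchanges methyl for chloro; each of them moves a methyl or changes the attachment of the five-membered ring, so none bears directly on this change. Among the compounds with values here, with no guiding step, a shift beyond the scatter is not expected, and the estimate for compound 4 is 70000 nM, within 25000 nM to 200000 nM, corresponding to the expected step of a 1.2-fold lower number from compound 3 to compound 4 (0.09 log units; within the scatter).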

Compound 4, half-maximal inhibitory concentration: > 100000 nM
Compound 4: a limit, no number (the forecaster's own chance of this, stated with the estimate: 35%); middle value at least 1.4-fold (0.15 log units) from the limit.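

In this assay compound 4 gives a limit and not a number, so chloro in place of methyl on this aromatic carbon next to the ring sulfur can only be bounded: an at least 1.1-fold higher number from compound 3 to compound 4 (0.06 log units; that floor lies within the scatter). The 5-chlorothiophen-2-yl group of compound 4 still stands clearly apart from the 3-methylthiophen-2-yl group of compound 2: an at least 9.0-fold higher number from compound 2 to compound 4 (0.95 log units; beyond the scatter). The step between compound 1 and compound 4 cannot be read, and a second compound now sits at the assay's ceiling: the limit of > 100000 nM in this assay, at which 2 of the 4 values shown sit.

The compounds shown leave open what number compound 4 would have, and so whether chloro and methyl differ at all on this read-out. They also leave open what an amine, a carboxylic acid or a longer chain would give in place of chloro on this aromatic carbon.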